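Swapping a dichlorophenyl group for a pyrrole side chain

The compounds below may be only part of what the source reports. "The series", "measured", "known", "first", "only" and "open" are said of these compounds alone.

compound 1 (`O=C(N/N=C/c1ccccc1)Nc1ccc(Oc2ccnc3[nH]ccc23)c(F)c1`) gives 7940 nM
compound 2 (`O=C(N/N=C/c1cccc(Cl)c1Cl)Nc1ccc(Oc2ccnc3[nH]ccc23)c(F)c1`) gives "not active" (no number reported)
compound 3 (`O=C(N/N=C/c1cccc(Cl)c1Cl)Nc1ccc(Oc2ccnc3[nH]ccc23)cc1`) gives "not active" (no number reported)

All three results come from a functional assay on PC-3 cells (Homo sapiens) for antiproliferative activity, read by MTT assay, with a stated time of 72 h (a higher number here means a weaker inhibitor, a lower number a stronger inhibitor), and only compound 1 has a measured figure. Compound 3 therefore has no exact place on the scale: it shares its reported outcome with compound 2, and neither can be ranked numerically against compound 1.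

The next structure is compound 4 (`CN(C)CCCn1cccc1/C=N/NC(=O)Nc1ccc(Oc2ccnc3[nH]ccc23)cc1`). The change is 1-(3-(dimethylamino)propyl)-1H-pyrrol-2-yl in place of 2,3-dichlorophenyl on a carbon with a double bond to nitrogen and in words it places 1-(3-(dimethylamino)propyl)-1H-pyrrol-2-yl where 2,3-dichlorophenyl stood on a carbon with a double bond to nitrogen.

The two compounds carrying 2,3-dichlorophenyl both lack a number, whereas compound 1 does not carry that group and reaches 7940 nM in this assay as a result. Within the data shown here, this is thin evidence from only three compounds, and none of them contains the incoming group. Even so, the expected step is towards stronger inhibition, from no measurable activity to a number in the neighbourhood of compound 1. Its exact size cannot be calculated without a figure for compound 3.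

Compound 4 is expected to read 5000 nM in this assay with an estimated range from 1000 nM to 25000 nM and a real chance of no number at all.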

Compound 4, half-maximal inhibitory concentration: 5150 nM
Estimate against measurement, compound 4: 1.0-fold (0.01 log units) below, within the range that was stated.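

In this assay compound 4 gives 5150 nM but compound 3 has no number, so the change between them cannot be expressed as a step. The compounds shown leave open how much 1-(3-(dimethylamino)propyl)-1H-pyrrol-2-yl changes activity relative to 2,3-dichlorophenyl. No measured property is available to explain the result of compound 4.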